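The compounds below may be only part of what the source reports. "The series", "measured", "known", "first", "only" and "open" are said of these compounds alone.

Compound 1 `C=C1CCC[C@]2(C)CCC(C=O)=CC[C@@]12C`: 152000 nM
Compound 2 `C=C1CCC[C@]2(C)CCC(c3cn(-c4ccc(OC)cc4)nn3)=CC[C@@]12C`: 58900 nM

In a functional assay on DU-145 cells (Homo sapiens) for cytotoxicity, read by MTT assay, with a stated time of 48 h (on this read-out lower numbers stand for stronger inhibition and higher numbers for weaker inhibition), compound 1 gives 152000 nM and compound 2 gives 58900 nM, the lowest of the two measured numbers. The gap between these two compounds lies beyond the scatter. Compound 3 `C=C1CCC[C@]2(C)CCC(c3cn(-c4ccc(C(C)=O)cc4)nn3)=CC[C@@]12C` keeps the shared core but carries acetyl in place of methoxy on an aromatic carbon, turning 4-methoxyphenyl into 4-acetylphenyl (acetyl in place of methoxy on an aromatic carbon). Among the measured compounds shown here, no measured pair shows what such an exchange does, so no step beyond the scatter is expected in this assay, in either direction. The expected change is small: a 1.2-fold lower number from compound 2 to compound 3 (0.07 log units; within the scatter). The estimate for compound 3 is 50000 nM, within an expected range of 20000 nM to 120000 nM.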

Compound 3, half-maximal inhibitory concentration: 51700 nM
Compound 3: the middle estimate sits 1.0-fold (0.01 log units) below what was measured; the measured number falls inside the stated range.
By their numbers in this assay, from the lowest: compounds 3 and 2 (each within the scatter of the next); then compound 1.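

In this assay, among the compounds shown here, acetyl in place of methoxy on an aromatic carbon, para to a large group, gives a 1.1-fold lower number from compound 2 to compound 3 (0.06 log units; within the scatter), the first exchange at this position that can be read. The two groups cannot be told apart here, so this change, which enters one more heavy atom and a carbonyl, leaves the number within the scatter. No measurement shown accounts for this result. Still open, from the compounds shown here alone, is whether an amine or a carboxylic acid at this position would move the number beyond the scatter.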